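Isopropoxy for isopropyl on the shared core

This account rests on a few compounds, and the source may have more. Where it says the series, first, only, none or still open, it means among the compounds named here.

Compound 1 `CCc1ccc2c(c1)[n+]([O-])c(NCCN(C)C)n[n+]2[O-]` carries an ethyl group on its core. In a physicochemical assay for solubility, in the presence of a further agent that is not named here (on this read-out higher numbers stand for higher solubility and lower numbers for lower solubility), compound 1 reaches only a limit, > 49000000 nM, which is the limit described by the limit of > 49000000 nM in this assay, at which 1 of the 2 values shown sits. Compound 2 `CC(C)c1ccc2c(c1)[n+]([O-])c(NCCN(C)C)n[n+]2[O-]` bears an isopropyl group instead, and in this assay compound 2 gives 42000000 nM. Among the measured compounds shown here, the one measured step, an at least 1.1-fold lower number from compound 1 to compound 2 (0.06 log units; that floor lies within the scatter), is a methyl on the saturated chain carbon. Compound 2 thus stands on the only plain number shown, the other value being a limit. Compound 3 `CC(C)Oc1ccc2c(c1)[n+]([O-])c(NCCN(C)C)n[n+]2[O-]` differs from compound 2 by isopropoxy in place of isopropyl on an aromatic carbon. For the measured compounds named here, no measured step exchanges carbon for oxygen at that position, so the expectation rests on the small size of the single step seen. For compound 3 a step of a 1.1-fold higher number from compound 2 to compound 3 (0.03 log units; within the scatter) is therefore expected, within the scatter. Compound 3 is estimated at 45000000 nM, with a range from 20000000 nM to 90000000 nM.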

Compound 3, solubility: > 51000000 nM
Compound 3 was reported as a limit (the forecaster's own chance of this, stated with the estimate: 40%); middle value at least 1.1-fold (0.05 log units) away from the limit.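

Placed on the aromatic carbon, isopropoxy in place of isopropyl adds a hydrogen-bond acceptor and an oxygen to the group, and in this assay this exchange gives an at least 1.2-fold higher number from compound 2 to compound 3 (0.08 log units; that floor lies within the scatter). So the first change of atom type at this position shows no step beyond the scatter, yet it gives only a floor and no size, and compound 3 is a limit, not a number: the limit of > 51000000 nM in this assay, at which 1 of the 3 values shown sits. The step between compound 1 and compound 3 cannot be read.

On these data alone, the true size of the exchange therefore remains open, as only compound 2 has a plain number in this assay. Also open, as far as these compounds go, is whether a group of another kind on this aromatic carbon, such as an amine, a carboxylic acid or a longer alkoxy chain, would give a plain number.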